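The source may hold more compounds than are shown below. What is called first, only, known or untested is meant among the compounds shown, and "the series" means these compounds.

Measured compounds:

Compound 1, `CC1CCC(=O)N1CC#CCn1ccnc1`: > 100 mg/kg
Compound 2, `Cc1cncn1CC#CCN1C(=O)CCC1C`: > 100 mg/kg
Compound 3, `O=C1OCCN1CC#CCn1ccnc1`: 3 mg/kg

In a functional assay on the whole organism for agonist activity, with Mus musculus as the target (a higher number here means that more compound is needed for the effect, a lower number that less compound is needed), compound 1 reaches only the upper limit, > 100 mg/kg, and no number is obtained. Compound 2 likewise sits at the limit of this assay, > 100 mg/kg. The step that the two limits leave unreadable from compound 1 to compound 2 is therefore not readable; the change itself is methyl in place of hydrogen on an aromatic carbon. Among the compounds with values here, compound 3 is the single compound of the set that gives a number, 3 mg/kg. Compound 1 and compound 2 sit at the limit of this assay, as stated in the limit of > 100 mg/kg in this assay, at which 2 of the 3 values shown sit. The difference between the core of compound 3 and the core of compound 1 is not broken down here.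

Compound 4, `Cc1cncn1CC#CCN1CCOC1=O`, is not yet measured. It stands to compound 3 as compound 2 stands to compound 1: the change is methyl in place of hydrogen on an aromatic carbon, and the place description is the same word for word in both pairs, so this is the same change.

Within the data shown here, the only measured instance of this change, from compound 1 to compound 2, lies between two limits and gives no size. The expectation for compound 4 therefore rests on the value of compound 3, 3 mg/kg, with a small methyl added and a wide band. The step of a 1.7-fold higher number from compound 3 to compound 4 (0.22 log units; within the scatter) is the expected one. For compound 4 the estimate in this assay is 5 mg/kg, with a range from 1.5 mg/kg to 20 mg/kg.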

Compound 4, dose for half-maximal effect: > 100 mg/kg
Compound 4: no number, only a limit (the forecaster's own chance of this, stated with the estimate: 15%); middle value at least 20-fold (1.30 log units) from the limit.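

In this assay, methyl in place of hydrogen on an aromatic carbon gives an at least 33-fold higher number from compound 3 to compound 4 (1.52 log units; beyond the scatter), so on the core of compound 3 this single change, one added carbon, is enough to lose the measurable effect seen for the unsubstituted imidazole-bearing parent, with no number left for the methyl compound. Compound 4 gives > 100 mg/kg, which is a limit of the assay and not a number. The same change on the core of compound 1 cannot be read, so the series holds only one readable instance and does not show that the change carries from one core to another with a similar size, while the full size of the readable step also stays unknown because its upper end is cut off: the limit of > 100 mg/kg in this assay, at which 3 of the 4 values shown sit.

The compounds shown leave open whether the loss is specific to methyl or would also follow from another group on the same aromatic carbon, such as ethyl, a longer chain, an amine or a carboxylic acid. They also leave open whether any replacement for that hydrogen keeps a readable dose on the core of compound 3.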